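From piperidin-1-yl to cyclopropylamino on the shared core

A few compounds are considered here, and "the series" means these few. Any claim that something is new, unique, unknown or untested is made for them only; others in the source may bear on it.

Compound 1 `Cc1ccc(NC2=CC(=O)c3c(nc4n3[C@H]3OC[C@@H](O)[C@H]3OC4)C2=O)cc1`: 6590 nM
Compound 2 `COc1ccccc1NC1=CC(=O)c2c(nc3n2[C@H]2OC[C@@H](O)[C@H]2OC3)C1=O`: 7460 nM
Compound 3 `O=C1C(N2CCCCC2)=CC(=O)c2c1nc1n2[C@H]2OC[C@@H](O)[C@H]2OC1`: > 16000 nM, a limit

In a functional assay on HeLa cells (Homo sapiens) for inhibition, read by sulforhodamine B assay (a higher number here means a weaker inhibitor, a lower number a stronger inhibitor), compound 3 gives only a limit, > 16000 nM, and no number. Compound 4 `O=C1C(NC2CC2)=CC(=O)c2c1nc1n2[C@H]2OC[C@@H](O)[C@H]2OC1` carries cyclopropylamino in place of piperidin-1-yl on a double-bonded ring carbon. For the measured compounds named here, two measured steps bear on this change, both ending in piperidin-1-yl: an at least 2.4-fold higher number from compound 1 to compound 3 (0.38 log units; beyond the scatter) and an at least 2.1-fold higher number from compound 2 to compound 3 (0.33 log units; beyond the scatter). Neither starts from cyclopropylamino, as they start from (4-methylphenyl)amino and (2-methoxyphenyl)amino, so they offer only a rough guide. Read in reverse, they point to a modest move towards a lower number. The expected size of the change is an at least 1.6-fold lower number from compound 3 to compound 4 (0.20 log units; that floor lies within the scatter). Compound 4 is estimated at 10000 nM, with an expected range from 4000 nM to 22000 nM.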

Compound 4, half-maximal inhibitory concentration: > 16000 nM
Compound 4: no number, only a limit (the forecaster's own chance of this, stated with the estimate: 30%); at least 1.6-fold (0.20 log units) between middle value and limit.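

In this assay compound 4 gives > 16000 nM, which is a limit and not a number. Replacing the aromatic group on the amine nitrogen with cyclopropyl gives an at least 2.1-fold higher number from compound 2 to compound 4 (0.33 log units; beyond the scatter) and an at least 2.4-fold higher number from compound 1 to compound 4 (0.38 log units; beyond the scatter), so the amine hydrogen shared by these three compounds does not by itself keep the values of compounds 1 and 2. The step between compound 3 and compound 4 cannot be read because both values are limits: the limit of > 16000 nM in this assay, at which 2 of the 4 values shown sit.

On these data alone, how far cyclopropylamino and piperidin-1-yl differ remains open. So does whether benzylamino or a longer chain on the amine nitrogen would give a measurable value.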